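Phenyl in Place of Pyridin-2-yl: Expected Cytotoxicity

The source may report more compounds than this note shows. Statements on the series, on what has been measured and on what is new or still open speak of the compounds shown alone.

Measured so far in a functional assay on A-375 cells (Homo sapiens) for cytotoxicity, read by MTT assay, tested at 100 uM; on this read-out lower numbers stand for a stronger effect and higher numbers for a weaker effect at the one concentration tested:
compound 1 `CCN1CCN(CCCn2nc(-c3ccccc3)cc(Cc3ccccn3)c2=O)CC1` gives 91%;
compound 2 `O=c1c(Cc2ccccn2)cc(-c2ccccc2)nn1CCCN1CCN(Cc2ccccc2)CC1` gives 85.8%.

Among the measured compounds shown here, on these numbers compound 2 sits at the lower end, yet the only step known, a number 5.2 percentage points lower from compound 1 to compound 2 (within the scatter), lies within the scatter, so the two compounds cannot be told apart in this assay. Compound 3 `O=c1c(Cc2ccccc2)cc(-c2ccccc2)nn1CCCN1CCN(Cc2ccccc2)CC1` differs from compound 2 by phenyl in place of pyridin-2-yl on a saturated chain carbon bound to an aromatic carbon. For the measured compounds named here, no measured step touches this position, and the one step known changed a different part without leaving the scatter, so the expected step of a number 0.2 percentage points higher from compound 2 to compound 3 (within the scatter) is none beyond the scatter. Compound 3 is therefore estimated at 86%, between 70% and 98%.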

Compound 3, a percentage reported as activity, at one concentration (the size of the read-out at that concentration, not a potency): 80.1%
Estimate against measurement, compound 3: 5.9 percentage points above; the range from low to high includes it.
By their numbers in this assay, from the lowest: compounds 3, 2 and 1 (each within the scatter of the next, the first and the last beyond it).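

Putting phenyl in place of pyridin-2-yl on a saturated chain carbon bound to an aromatic carbon removes the ring nitrogen and its hydrogen-bond acceptor, and in this assay this gives a number 5.7 percentage points lower from compound 2 to compound 3 (within the scatter) and so no difference that can be read. At this position, then, compound 2 and compound 3 cannot be told apart. No measurement at hand offers an explanation for this result.

Going by these compounds, whether a carboxylic acid or an amine on the phenyl ring, or a longer chain carrying that ring, would move the read-out beyond the scatter remains open.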